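The source may hold more compounds than are shown below. What is called first, only, known or untested is meant among the compounds shown, and "the series" means these compounds.

Measured so far in a functional assay on 1321-N1 cells for agonist activity at Free fatty acid receptor 1 (Homo sapiens), read by calcium flux; on this read-out lower numbers stand for smaller maximal responses and higher numbers for larger maximal responses:
compound 1 `O=C(O)CCc1ccc(NCc2ccccc2)cc1` — 89%
compound 2 `O=C(O)CCc1ccc(NCc2cccc(Br)c2)cc1` — 110%

Within the data shown here, compound 1 gives the lower of the two numbers in this assay; its one neighbour, compound 2, carries bromo in place of hydrogen on an aromatic carbon and shows a number 21 percentage points higher from compound 1 to compound 2 (beyond the scatter). Compound 3 `O=C(O)CCc1ccc(NCc2ccccc2-c2ccccc2)cc1` differs from compound 1 by phenyl in place of hydrogen on an aromatic carbon. Among the measured compounds shown here, only that one step bears on the new compound, and it concerns another group, so it is a weak guide. A small rise in this assay is expected for compound 3, a number 11 percentage points higher from compound 1 to compound 3 (beyond the scatter), possibly within the scatter. Compound 3 is estimated at 100%, between 80% and 120%.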

Compound 3, largest response reached (reported as efficacy), in percent of the reference or control that the assay uses: 97%
For compound 3 the middle estimate is 3 percentage points above the measured one; the range from low to high includes it.
By their numbers in this assay, from the lowest: compounds 1 and 3 (each within the scatter of the next); then compound 2.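

Going from hydrogen to phenyl on an aromatic carbon ortho to a large group, this assay shows a number 8 percentage points higher from compound 1 to compound 3 (within the scatter) and so gives no sign of a change in maximal response. This position therefore accepts an added aromatic ring of 6 heavy atoms with the response of compound 1 retained. No measurement that could explain this result accompanies the series.

Open, going by these compounds, is whether methyl, methoxy or a pyridine ring on this carbon would also retain the response. Also open, on these data alone, is how phenyl would behave at the place that carries bromo in compound 2.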